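Chloro for tert-butyl on a shared quinoline-free core

The source may report more compounds than this note shows. Statements on the series, on what has been measured and on what is new or still open speak of the compounds shown alone.

Measured so far:
compound 1, `CC(C)(C)c1ccc(Oc2ccc3c(NCCCNCc4ccco4)ccnc3c2)cc1`: 3100 nM
compound 2, `COc1cccc(CNCCCNc2ccnc3cc(Cc4cccc(C(F)(F)F)c4)ccc23)c1O`: 1720 nM

In an ADME assay on HepG2 cells (Homo sapiens) for cytotoxicity, read by luminescence, CellTiter-Glo and ATP content, with a stated time of 72 h (on this read-out higher numbers stand for an effect only at larger amounts of compound and lower numbers for an effect already at smaller amounts), compound 1 gives 3100 nM, the highest of the two numbers shown, while compound 2 gives 1720 nM, a gap that lies within the scatter. Compound 3, `Clc1ccc(Oc2ccc3c(NCCCNCc4ccco4)ccnc3c2)cc1`, has not yet been measured. It differs from compound 1 by chloro in place of tert-butyl on an aromatic carbon. Among the compounds with values here, with no measured step of this kind at hand, only a modest shift is expected: compound 3 is estimated at 4500 nM, between 1500 nM and 13000 nM, an expected step of a 1.5-fold higher number from compound 1 to compound 3 (0.16 log units; within the scatter).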

Compound 3, half-maximal effective concentration: 7800 nM
Compound 3: the middle estimate sits 1.7-fold (0.24 log units) below what was measured; the measured number falls inside the stated range.
By their numbers in this assay, from the lowest: compounds 2 and 1 (each within the scatter of the next); then compound 3.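

In this assay, chloro in place of tert-butyl gives a 2.5-fold higher number from compound 1 to compound 3 (0.40 log units; beyond the scatter), the only step shown at this position and one that lies beyond the scatter. This aromatic carbon, para to a large group, therefore registers a change of group on the shared core, with the single chlorine atom giving the higher number. No measured evidence at hand bears on the reason for this shift. As far as these compounds go, what stays open is where fluoro or an amine at this carbon would fall relative to chloro and tert-butyl. One step also cannot show whether the same change would give a similar shift on another core.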